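Compound 3 to compound 4: a new group on the amine nitrogen

This account rests on a few compounds, and the source may have more. Where it says the series, first, only, none or still open, it means among the compounds named here.

In a functional assay on HepG2 cells (Homo sapiens) for inhibition, read by MTT assay, with a stated time of 48 h (a higher number here means a weaker inhibitor, a lower number a stronger inhibitor), compound 3 (`CCOC(=O)C1=C(N/N=C(/C(=O)Br)c2ccc(Cl)cc2)Nc2[nH]nc(C)c2C1c1ccc(N(C)C)cc1`) gives 50300 nM. Compound 1 (`CCOC(=O)C1=C(N/N=C(/C#N)C(=O)OCC)Nc2[nH]nc(C)c2C1c1ccc(N(C)C)cc1`) gives 46400 nM, so the two stand level, and compound 2 (`CCOC(=O)C1=C(N/C=N/c2ncc(-c3ccccc3)s2)Nc2[nH]nc(C)c2C1c1ccc(N(C)C)cc1`) gives a clearly lower 9790 nM. Compound 4 (`CCOC(=O)C1=C(N/C=N/c2ccc([N+](=O)[O-])cc2)Nc2[nH]nc(C)c2C1c1ccc(N(C)C)cc1`) differs from compound 3 by a group of 11 heavy atoms (7 carbon, 2 nitrogen, 2 oxygen; one six-membered aromatic ring of carbon only) in place of a group of 12 heavy atoms (8 carbon, 1 nitrogen, 1 oxygen, 1 chlorine, 1 bromine; one six-membered aromatic ring of carbon only), on an amine nitrogen. Within the data shown here, the only measured step at this amine nitrogen, a 1.1-fold higher number from compound 1 to compound 3 (0.04 log units; within the scatter), shows no change beyond the scatter, even though the group there was exchanged. However, compound 4 shares its linking atoms with compound 2, at 9790 nM. A moderate fall in this assay is therefore expected, an estimated 2.8-fold lower number from compound 3 to compound 4 (0.45 log units; beyond the scatter). For compound 4 the estimate is 18000 nM, with an expected range of 7000 nM to 45000 nM.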

Compound 4, half-maximal inhibitory concentration: 50900 nM
The estimate for compound 4 lay 2.8-fold (0.45 log units) below the measured number; measured number above the stated range.
By their numbers in this assay, from the lowest: compound 2; then compounds 1, 3 and 4 (each within the scatter of the next).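

In this assay, the linking atoms shared with compound 2 do not by themselves bring its lower number: a 5.2-fold higher number from compound 2 to compound 4 (0.72 log units; beyond the scatter) accompanies 4-nitrophenyl in place of 5-phenyl-1,3-thiazol-2-yl on a double-bonded nitrogen. Exchanging the whole group on the amine nitrogen leaves the other numbers level, with a 1.0-fold higher number from compound 3 to compound 4 (0.01 log units; within the scatter) and a 1.1-fold higher number from compound 1 to compound 4 (0.04 log units; within the scatter), so the terminal group on that link now matters as much as the link. No measurement on hand explains the gap between compound 2 and compound 4. Still open, on these data alone, is whether the thiazole ring or its phenyl goes with the lower number of compound 2, and how an amine in place of the nitro group would read.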